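This account rests on a few compounds, and the source may have more. Where it says the series, first, only, none or still open, it means among the compounds named here.

Of the compounds shown here, two with a shared core have been measured in an assay for inhibition of RAC-alpha serine/threonine-protein kinase (Homo sapiens), read by HTRF, with a stated time of 1 h; a higher number here means a weaker inhibitor, a lower number a stronger inhibitor. Compound 1 `Cn1ncc(Cl)c1-c1cc(C(=O)N[C@@H]2CN[C@H](CC(O)CO)C[C@H]2c2ccc(F)c(F)c2)oc1Cl` gives 3.31 nM. Compound 2 `C=CC[C@@H]1C[C@@H](c2ccc(Cl)c(Cl)c2)[C@H](NC(=O)c2cc(-c3c(Cl)cnn3C)c(Cl)o2)CN1` gives 12.4 nM, the higher of the two numbers, and the gap to compound 1 lies beyond the scatter; since compound 1 differs from compound 2 in more than one place, no single change can be credited for that gap. Compound 3 `Cn1ncc(Cl)c1-c1cc(C(=O)N[C@@H]2CN[C@H](CC(=O)NCCO)C[C@H]2c2ccc(Cl)c(Cl)c2)oc1Cl` is the next compound. Compared with compound 2 it carries (2-hydroxyethyl)carbamoyl in place of vinyl on a saturated chain carbon bound to a saturated ring carbon. Going by the values given here, no measured pair shows this exact change, so the expected size of the step rests on the two numbers above. Compound 3 is expected to give a somewhat lower number than compound 2, because compound 1 with its hydroxylated chain gives 3.31 nM. For compound 3 the expected step from compound 2 is a 2.1-fold lower number from compound 2 to compound 3 (0.32 log units; beyond the scatter), in this assay. The estimated value for compound 3 is 6 nM, with a range from 2 nM to 18 nM.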

Compound 3, half-maximal inhibitory concentration: 1.41 nM
Compound 3: the middle estimate sits 4.3-fold (0.63 log units) above what was measured, and the stated range ends above it.
By their numbers in this assay, from the lowest: compound 3; then compound 1; then compound 2.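

On a saturated chain carbon bound to a saturated ring carbon, (2-hydroxyethyl)carbamoyl in place of vinyl gives an 8.8-fold lower number from compound 2 to compound 3 (0.94 log units; beyond the scatter) in this assay. Going by these compounds alone, this is the first step at this position that can be read from a single change, and it shows that the position accepts the larger group, with its hydrogen-bond donors and acceptors, while the number falls rather than rises. No evidence is available to say which part of the entering group accounts for the step.

The compounds shown leave open whether the carbonyl and amide hydrogen alone would be enough, as a plain methyl amide would test, or whether the terminal hydroxyl is needed. Also open, from the compounds shown here alone, is how a carboxylic acid, a primary amine or a longer chain would read at the same place.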